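The source may hold more compounds than are shown below. What is called first, only, known or untested is meant among the compounds shown, and "the series" means these compounds.

Measured in a functional assay on MGC-803 cells (Homo sapiens) for antiproliferative activity, read by MTT assay, with a stated time of 72 h; a lower number here means a stronger inhibitor, a higher number a weaker inhibitor:
Compound 1 `O=C(COc1ccc(C(=O)/C=C/c2ccc(F)c(F)c2)cc1)N[C@H]1CCOC1=O`: > 64000 nM, a limit
Compound 2 `O=C(COc1ccc(C(=O)/C=C/c2ccc(F)cc2)cc1)N[C@H]1CCOC1=O`: > 64000 nM, a limit
Compound 3 `O=C(COc1ccc(C(=O)/C=C/c2ccccc2)cc1)N[C@H]1CCOC1=O`: > 64000 nM, a limit

Compound 3 stands at > 64000 nM, which is a limit and not a number. It shares this position with the other two measured compounds, as the record shows: the limit of > 64000 nM in this assay, at which 3 of the 3 values shown sit.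

Compound 4 `O=C(COc1ccc(C(=O)/C=C/c2ccccc2Br)cc1)N[C@H]1CCOC1=O` differs from compound 3 by bromo in place of hydrogen on an aromatic carbon, ortho to a large group: bromo in place of hydrogen on an aromatic carbon. The cut one bond further out reads phenyl to 2-bromophenyl.

The nearest measured changes also concern a substituent on an aromatic carbon. They are a step that the two limits leave unreadable from compound 1 to compound 2 and a step that the two limits leave unreadable from compound 2 to compound 3, and together they make a step that the two limits leave unreadable from compound 1 to compound 3. None of these has a readable size, so the series offers no measured effect of such a change in either direction. On that basis, no shift beyond the usual scatter is expected in this assay, and another limit is the most likely report. The expected step is a number no higher from compound 3 to compound 4 (the limit leaves the size open). For compound 4 the estimate is 64000 nM, with an expected range from 30000 nM to 128000 nM.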

Compound 4, half-maximal inhibitory concentration: 12200 nM
The estimate for compound 4 lay 5.2-fold (0.72 log units) above the measured number; the whole stated range lies above it.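

In this assay, bromo on an aromatic carbon, ortho to a large group, is the only change shown with a readable effect: an at least 5.2-fold lower number from compound 3 to compound 4 (0.71 log units; beyond the scatter). The 2-bromophenyl group gives the same reading against the 4-fluorophenyl and 3,4-difluorophenyl groups, with an at least 5.2-fold lower number from compound 2 to compound 4 (0.71 log units; beyond the scatter) and an at least 5.2-fold lower number from compound 1 to compound 4 (0.71 log units; beyond the scatter), whereas the steps among compound 1, compound 2 and compound 3 cannot be read. Each of the three new steps gives only a minimum size, since the other three compounds all stand at one limit: the limit of > 64000 nM in this assay, at which 3 of the 4 values shown sit.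

The compounds shown leave open whether the drop in the number depends on bromo itself or on this position, as bromo appears at no other place on the ring and no chloro, methyl or methoxy group stands at this one. They also leave open how an amine or a carboxylic acid at this place would read, and whether the 2-bromophenyl group would give a similar step with a longer chain in place of the link to the amide.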